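The source may hold more compounds than are shown below. What is called first, only, known or untested is meant among the compounds shown, and "the series" means these compounds.

Measured so far in a functional assay on NCI-H23 cells (Homo sapiens) for inhibition, read by sulforhodamine B assay; on this read-out higher numbers stand for weaker inhibition of growth and lower numbers for stronger inhibition of growth:

compound 1 `CC(C)(C)c1ccc(CCCN2CC=C(CCC(=O)NO)C2=O)cc1` gives 2520 nM
compound 2 `O=C(CCC1=CCN(Cc2ccc(Cl)cc2)C1=O)NO` gives 2500 nM
compound 3 `N#Cc1ccc(CN2CC=C(CCC(=O)NO)C2=O)cc1` gives 2320 nM

Compound 1 stands at the highest of the three numbers, but its gaps to compound 2 and to compound 3 are both within the scatter, so the three measured compounds cannot be told apart on this read-out. Going by the values given here, the one step between measured compounds that differ in a single place, a 1.1-fold lower number from compound 2 to compound 3 (0.03 log units; within the scatter), is likewise within the scatter.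

Compound 4 `Cc1ccc(CCCN2CC=C(CCC(=O)NO)C2=O)cc1` is the next compound of the series. It differs from compound 1 in one place: methyl in place of tert-butyl on an aromatic carbon. Among the compounds with values here, no measured step concerns the tert-butyl or the methyl group; the only step that exists, cyano in place of chloro on an aromatic carbon, changes a different group and is itself flat. Within the data shown here, with every number so far sitting at the same level and the only known substituent change on the aryl ring showing no effect, the expectation for the step of a 1.0-fold lower number from compound 1 to compound 4 (0.00 log units; within the scatter) is no change beyond the scatter, in either direction. Compound 4 is therefore estimated at 2500 nM in this assay, within a range of 1200 nM to 5500 nM.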

Compound 4, concentration for 50% growth inhibition: 2520 nM
Compound 4: the middle estimate sits 1.0-fold (0.00 log units) below what was measured; low and high end bracket the measured number.
By their numbers in this assay, from the lowest: compounds 3, 2, 1 and 4 (each within the scatter of the next).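

In this assay, methyl in place of tert-butyl on the aromatic carbon para to a large group gives no change at the digits printed from compound 1 to compound 4 (within the scatter). Going by these compounds alone, this is the first measured step at this substituent, and going from 4 heavy atoms to 1 heavy atom, all carbon and with no ring, no charge and no hydrogen-bond donors or acceptors on either side, leaves the read-out flat for this pair. No measurement at hand offers a reason for this flat step.

Still open, as far as these compounds go, is whether the number stays at this level with an amine, a methoxy group or a carboxylic acid at this place on the aromatic ring, since both groups compared here are plain alkyl groups. Also open is whether a longer chain linking the aromatic ring to the shared core, or a carboxylic acid in place of the hydroxamic acid, would move the number beyond the scatter in this growth read-out, which so far has shown no step of that size.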